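Cutting back compound 1: what to expect of compound 4

This account rests on a few compounds, and the source may have more. Where it says the series, first, only, none or still open, it means among the compounds named here.

compound 1 `Cc1cc(C)c(S(=O)(=O)N2CCC(N3CCC(CCO)CC3)CC2)c(C)c1` gives 19 nM
compound 2 `Cc1cc(C)c(S(=O)(=O)N2CCC(N3CCC(CCC#N)CC3)CC2)c(C)c1` gives > 5000 nM as a limit of the assay
compound 3 `C#CCCC(=O)CC1CCN(C2CCN(S(=O)(=O)c3c(C)cc(C)cc3C)CC2)CC1` gives 3 nM

In a functional assay on DLD-1 cells (Homo sapiens) for antiproliferative activity, read by CellTiter-Glo, with a stated time of 72 h (on this read-out lower numbers stand for stronger inhibition and higher numbers for weaker inhibition), compound 1 stands at 19 nM and holds the higher of the two true numbers. The gap to the other number is a 6.3-fold lower number from compound 1 to compound 3 (0.80 log units; beyond the scatter) and counts as a modest step. Compound 2 reached only a limit of the assay, so its entry is not a true number. The step to that limit is an at least 260-fold higher number from compound 1 to compound 2 (2.42 log units; beyond the scatter) and is large.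

Compound 4 `CCCC(=O)NC1CCN(S(=O)(=O)c2c(C)cc(C)cc2C)CC1` has not yet been measured. Its change from compound 1 is far broader than either step: (propylcarbonyl)amino in place of 4-(2-hydroxyethyl)piperidin-1-yl on a saturated ring carbon and so (propylcarbonyl)amino stands in place of 4-(2-hydroxyethyl)piperidin-1-yl on a saturated ring carbon. The measured steps only altered the end of the chain on the group that now leaves, yet they moved the number in both directions. Going by the values given here, the larger move from compound 1 was upward, an at least 260-fold higher number from compound 1 to compound 2 (2.42 log units; beyond the scatter) and so a rise is expected here too, although no measured step covers a change this broad. The expected step is a 42-fold higher number from compound 1 to compound 4 (1.62 log units; beyond the scatter) and its size is very uncertain. Compound 4 is estimated at 800 nM with an expected range from 60 nM to 10000 nM in this test, and a reading that gives only a limit is possible.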

Compound 4, half-maximal inhibitory concentration: > 5000 nM
Compound 4 ended at the assay's limit (the forecaster's own chance of this, stated with the estimate: 35%); at least 6.2-fold (0.79 log units) between middle value and limit.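

In this assay, compound 4 stands at a limit of the assay, > 5000 nM, and not at a true number. The earlier steps shown here changed only the end of the chain and kept the 4-substituted piperidine, whereas this one replaces the whole 4-(2-hydroxyethyl)piperidin-1-yl group with (propylcarbonyl)amino on the same saturated ring carbon and gives an at least 260-fold higher number from compound 1 to compound 4 (2.42 log units; beyond the scatter), so the core of compound 1 carrying this shorter, ring-free group does not retain the activity of compound 1 in this test. The printed size of this step is set by a limit, so its real size stays unknown: the limit of > 5000 nM in this assay, at which 2 of the 4 values shown sit.

The piperidine ring, its nitrogen and the chain end all change together in this step, so the compounds shown do not tell which of these parts accounts for the loss of activity. A plain piperidin-1-yl group without a chain, a simple amine on that ring carbon, or a longer chain on the amide carbonyl would each test one of these parts on its own.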